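Shrinking a Seven-Membered Ring to a Short Chain

The compounds below may be only part of what the source reports. "The series", "measured", "known", "first", "only" and "open" are said of these compounds alone.

Measured compounds:
Compound 1 `O=C(O)c1ccccc1-c1ccc(CCc2ncc(CCC3CCCCC3)[nH]2)cc1` gives 642 nM in an in vitro functional assay on cells for agonist activity at Bombesin receptor subtype-3 (Homo sapiens), read by luminescence and calcium flux; a higher number here means that more compound is needed for the effect, a lower number that less compound is needed.
Compound 2 `CCCCc1cnc(C(CC)Cc2ccc(-c3ccccc3C(=O)O)cc2)[nH]1` gives 2720 nM in this assay.
Compound 3 `O=C(O)c1ccccc1-c1ccc(CCc2ncc(CC3CCCCCC3)[nH]2)cc1` gives 88 nM in this assay.

Among these three, compound 3 has the lowest number, so it needs the least compound of the set to reach the half-maximal effect. Among the measured compounds shown here, the next one up is compound 1, and the single step between them is a 7.3-fold lower number from compound 1 to compound 3 (0.86 log units; beyond the scatter). The furthest away is compound 2, whose number lies well beyond the scatter above that of compound 3.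

The unmeasured compound 4 `CCCCc1cnc(CCc2ccc(-c3ccccc3C(=O)O)cc2)[nH]1` differs from compound 3 in one place: propyl in place of cycloheptyl on a saturated chain carbon bound to an aromatic carbon. For the measured compounds named here, the one measured step bears on it only indirectly, since it compared two saturated rings rather than a ring against an open chain. Compound 2 carries the same propyl on that carbon but also an extra ethyl, so its value can only hint at the direction. Taken together, a move away from the cycloheptyl seems more likely to raise the number than to lower it, and by more than the scatter.

Compound 4 is therefore expected to give about 1500 nM, with a plausible range from 500 nM to 5000 nM. This expectation amounts to a 17-fold higher number from compound 3 to compound 4 (1.23 log units; beyond the scatter).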

Compound 4, half-maximal effective concentration: 2710 nM
Beside the measured number, compound 4's estimate is 1.8-fold (0.26 log units) below it; measured number inside the range.
By their numbers in this assay, from the lowest: compound 3; then compound 1; then compounds 4 and 2 (each within the scatter of the next).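

In this assay, among the compounds shown here, a 31-fold higher number from compound 3 to compound 4 (1.49 log units; beyond the scatter) gives the first direct comparison of a saturated ring with an open chain at this position, and the open propyl comes out clearly behind the cycloheptyl. The ring with its extra carbons is not the only one to compare favourably with this chain, since ethyl in place of cyclohexyl, the change that links compound 1 to the open-chain compound, gives a 4.2-fold higher number from compound 1 to compound 4 (0.63 log units; beyond the scatter) in the same direction, so both ring-bearing compounds shown have lower numbers than compound 4. The step of a 1.0-fold lower number from compound 2 to compound 4 (0.00 log units; within the scatter), hydrogen in place of ethyl on a saturated chain carbon bound to an aromatic carbon and a saturated chain carbon, shows no readable difference, which means that, with this open chain in place, the ethyl leaves the number where it was.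

Nothing measured here explains why the ring-bearing compounds have the lower numbers. For the compounds shown here, it also remains open whether the ring itself or only its carbon count matters, which a longer chain such as heptyl in place of cycloheptyl would test, and whether the ethyl would still make no difference in a compound carrying the cycloheptyl.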